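The source may report more compounds than this note shows. Statements on the series, on what has been measured and on what is new or still open speak of the compounds shown alone.

Of the compounds shown here, three built on one shared core have so far been measured in a functional assay on K562 cells (Homo sapiens) for antiproliferative activity, read by MTT assay, with a stated time of 48 h; on this read-out higher numbers stand for weaker inhibition and lower numbers for stronger inhibition. Compound 1 `COc1ccc(CN2C(=O)C(=O)c3cc(-c4cccc(OC)c4)ccc32)cc1` gives 100 nM, compound 2 `COc1ccc(CN2C(=O)C(=O)c3cc(-c4ccc(F)cc4)ccc32)cc1` gives 240 nM, and compound 3 `COc1ccc(CN2C(=O)C(=O)c3cc(-c4ccc(F)c(Cl)c4)ccc32)cc1` gives 380 nM, the highest number of the three: it lies within the scatter of compound 2 but clearly apart from compound 1. Compound 4 `COc1ccc(CN2C(=O)C(=O)c3cc(-c4ccc5ccccc5c4)ccc32)cc1` differs from compound 3 by naphthalen-2-yl in place of 3-chloro-4-fluorophenyl on an aromatic carbon. Among the compounds with values here, the steps that bear on this change all exchange the group at the same position: a 2.4-fold higher number from compound 1 to compound 2 (0.38 log units; beyond the scatter), a 3.8-fold higher number from compound 1 to compound 3 (0.58 log units; beyond the scatter) and a 1.6-fold higher number from compound 2 to compound 3 (0.20 log units; within the scatter). All were modest or within the scatter, and none involved a fused two-ring group, so only a modest step in either direction is expected. Compound 4 is estimated at 250 nM, within 80 nM to 800 nM, which means an expected 1.5-fold lower number from compound 3 to compound 4 (0.18 log units; within the scatter).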

Compound 4, half-maximal inhibitory concentration: 340 nM
Estimate against measurement, compound 4: 1.4-fold (0.13 log units) below, and the stated range covers the measured number.
By their numbers in this assay, from the lowest: compound 1; then compounds 2, 4 and 3 (each within the scatter of the next).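

Naphthalen-2-yl, a fused two-ring group at this position, stays within the scatter of both halogen-bearing phenyl groups (a 1.1-fold lower number from compound 3 to compound 4 (0.05 log units; within the scatter); a 1.4-fold higher number from compound 2 to compound 4 (0.15 log units; within the scatter)). The second fused ring therefore leaves 3-methoxyphenyl as the only group shown that stands apart (a 3.4-fold higher number from compound 1 to compound 4 (0.53 log units; beyond the scatter)). No measurement offered here explains these numbers. Still open, as far as these compounds go, is whether an amine or a carboxylic acid on the aryl ring at this position would move the number, and whether a longer chain such as ethoxy in place of the methoxy of compound 1 would keep its lower number.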